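A few compounds are considered here, and "the series" means these few. Any claim that something is new, unique, unknown or untested is made for them only; others in the source may bear on it.

Measured so far:
compound 1 `Fc1ccc(-c2cn3nc(Cc4ccc(Cl)cc4)sc3n2)cc1` — > 250000 nM (a limit of the assay)
compound 2 `Clc1ccc(Cc2nn3cc(-c4ccc(Br)cc4)nc3s2)cc1` — > 250000 nM (a limit of the assay)

In a functional assay on HeLa cells (Homo sapiens) for cytotoxicity, with a stated time of 72 h (a lower number here means a stronger inhibitor, a higher number a weaker inhibitor), compound 1 gives > 250000 nM, which is a limit of the assay and not a number. Compound 2 gives > 250000 nM, likewise a limit. So compound 1 stands nowhere on a scale of numbers: all that is known is the limit of > 250000 nM in this assay, at which 2 of the 2 values shown sit. Among the compounds with values here, the one step between measured compounds, a step that the two limits leave unreadable from compound 1 to compound 2, therefore has no readable size.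

Compound 3 `Fc1ccc(-c2nc3sc(Cc4ccc(Cl)cc4)nn3c2Br)cc1` is the not-yet-measured partner of compound 1. The change is bromo in place of hydrogen on an aromatic carbon. Within the data shown here, no measured step resembles it, and the two known values give no direction at all. The expectation for compound 3 is that it behaves like compound 1, so the step from compound 1 to compound 3 is estimated as a step that the limit leaves unreadable from compound 1 to compound 3, most likely again only a limit. The estimate for compound 3 in this assay is 300000 nM, in a range from 50000 nM to 1500000 nM.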

Compound 3, half-maximal inhibitory concentration: > 250000 nM
Compound 3: no number, only a limit; the forecaster's own chance of this, stated with the estimate: 80%; the middle value does not contradict the limit.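

In this assay compound 3 gives > 250000 nM, a limit of the assay and not a number. The step from compound 1 to compound 3 therefore cannot be read. The compounds shown leave open whether any change to this shared core gives a measurable value: the limit of > 250000 nM in this assay, at which 3 of the 3 values shown sit.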